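From compound 2 to compound 3: a reshaped piperazine side chain

The source may hold more compounds than are shown below. What is called first, only, known or untested is meant among the compounds shown, and "the series" means these compounds.

- compound 1 `CC(C)N1CCN(CCCN(C[C@H]2Cc3ccccc3CN2)[C@H]2CCCc3cccnc32)CC1`: 4%
- compound 2 `CCN1CCN(CCCN(C[C@H]2Cc3ccccc3CN2)[C@H]2CCCc3cccnc32)CC1`: 1%

Both compounds were tested in an ADME assay on microsomes from liver (Rattus norvegicus) for metabolic stability, read by LC-MS, with a stated time of 10 min, tested at 0.5 uM; on this read-out lower numbers stand for a less stable compound and higher numbers for a more stable compound. Compound 2 gives 1%, so very little of it is left at the end of the test, and it cannot be told apart from compound 1, which gives 4%.

The next compound to be tested is compound 3 `c1ccc2c(c1)CN[C@@H](CN(CCCCN1CCNCC1)[C@H]1CCCc3cccnc31)C2`. Its structural change is (piperazin-1-yl)methyl in place of 4-ethylpiperazin-1-yl on a saturated chain carbon, three bonds along the chain from an amine nitrogen. The same change can be read as 3-(4-ethylpiperazin-1-yl)propyl to 4-(piperazin-1-yl)butyl, on the same shared core.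

Among the measured compounds shown here, only one measured step bears on this change: a number 3 percentage points lower from compound 1 to compound 2 (within the scatter). That step puts hydrogen in place of methyl on a saturated chain carbon bound to an amine nitrogen in a ring, and it is small. For the measured compounds named here, no measured step covers the removal of the whole ethyl group or a longer chain, so this evidence is thin. A step beyond the scatter is therefore not expected. The expected change is a number 3 percentage points higher from compound 2 to compound 3 (within the scatter). For compound 3 the estimated value is 4%, with an expected range from 0% to 14%.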

Compound 3, percent of the compound remaining: 15%
Estimate against measurement, compound 3: 11 percentage points below, and the stated range ends below it.
By their numbers in this assay, from the lowest: compounds 2 and 1 (each within the scatter of the next); then compound 3.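

In this assay the change gives a number 14 percentage points higher from compound 2 to compound 3 (beyond the scatter) and a number 11 percentage points higher from compound 1 to compound 3 (beyond the scatter) and so, unlike the small step between the two earlier compounds, shows that the number can move when this side chain is altered. The rise is modest, and compound 3 at 15% still has most of its starting amount gone by the end of the test. The step also joins two alterations, since the ethyl group on the piperazine ring is gone and the chain reads 4-(piperazin-1-yl)butyl instead of 3-(4-ethylpiperazin-1-yl)propyl, and nothing measured here explains why the number rises.

The compounds shown leave open which of the two alterations carries the rise, a question that a piperazine free of the ethyl group on the propyl chain, or a 4-(4-ethylpiperazin-1-yl)butyl chain, would address. They also leave open what happens with a still longer chain or with a morpholine ring in place of the piperazine ring.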